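Cytotoxicity notes on compounds 1 to 4

This account rests on a few compounds, and the source may have more. Where it says the series, first, only, none or still open, it means among the compounds named here.

Compound 1 `CCCCOc1c(NCCCNc2cc(OC)cc3cccnc23)c(=O)c1=O` and compound 2 `CCCCOc1c(NCCC(C)Nc2cc(OC)cc3cccnc23)c(=O)c1=O` share one core; compound 3 `COc1cc(NC(C)CCCNc2c(OC)c(=O)c2=O)c2ncccc2c1` carries another, and the difference between the two cores is not broken down here. Compound 4 `CCOc1c(NCCCC(C)Nc2cc(OC)cc3cccnc23)c(=O)c1=O` is not yet measured. In an ADME assay on HEK-293T cells (Homo sapiens) for cytotoxicity, read by MTT assay, with a stated time of 48 h (a higher number here means a weaker inhibitor, a lower number a stronger inhibitor), compound 1 gives > 100000 nM, a limit of the assay. In this assay compound 2 gives > 100000 nM, also a limit. The step that the two limits leave unreadable from compound 1 to compound 2 is made by methyl in place of hydrogen on a saturated chain carbon bound to a nitrogen on an aromatic ring and a saturated chain carbon. For compound 3 the result in this assay is "not determined" (no result reported). The change from compound 3 to compound 4 is methyl in place of hydrogen on a saturated chain carbon bound to an oxygen on an aromatic ring, the same kind of change as from compound 1 to compound 2, though the place differs: here the carbon is bound to an oxygen on an aromatic ring, there to a nitrogen on an aromatic ring and a saturated chain carbon. Because compound 1 and compound 2 both sit at the limit of > 100000 nM in this assay, at which 2 of the 3 values shown sit, compound 4 is expected to sit at a limit too, estimated at 150000 nM with a range of 60000 nM to 400000 nM.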

Compound 4, half-maximal inhibitory concentration: > 100000 nM
Compound 4 gave a limit, no number; the forecaster's own chance of this, stated with the estimate: 85%; the middle value lies beyond the limit too.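

In this assay compound 4 gives > 100000 nM, a limit of the assay, so no new step can be read between compound 3 and compound 4. The compounds shown leave open whether any member of the series gives a readable number in this assay.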